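The source may report more compounds than this note shows. Statements on the series, on what has been measured and on what is new or still open speak of the compounds shown alone.

Among the compounds with values here, compound 1 `CCNCCn1c(N2CCN(C)CC2)nc2ccccc21` is one of three compounds measured in a functional assay on ileum for inhibition of histamine H1 receptor (Cavia porcellus); a lower number here means a stronger inhibitor, a higher number a weaker inhibitor. In this assay compound 1 gives 290 nM, the highest number of the three. Compound 2 `CCCCN1CCN(c2nc3ccccc3n2CCOCC)CC1` gives 15 nM, and compound 3 `CCCN1CCCN(c2nc3ccccc3n2CCOCC)CC1` gives 8.4 nM; both differ from compound 1 in more than one place, so their gaps to compound 1 are read only as what the two numbers show, and each gap lies beyond the usual scatter.

Compound 4 `CN1CCN(c2nc3ccccc3n2CCOc2ccccc2)CC1` has not been measured. It differs from compound 1 in a single place: phenoxy in place of ethylamino on a saturated chain carbon, two bonds along the chain from an aromatic nitrogen. The side chain on the aromatic nitrogen thereby loses its hydrogen-bond donor and gains a six-membered aromatic ring, while the shared core and the methyl-bearing ring on the other side stay as they are.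

Within the data shown here, no single-change step between measured compounds is available to lean on. Because compound 2 with 15 nM and compound 3 with 8.4 nM show that side chains without the ethylamino group go with far lower numbers, the step from compound 1 to compound 4 is expected to be a drop beyond the scatter, a 9.7-fold lower number from compound 1 to compound 4 (0.99 log units; beyond the scatter). For compound 4 the expected value in this assay is 30 nM, within a range of 8 nM to 120 nM.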

Compound 4, half-maximal inhibitory concentration: 6.9 nM
Compound 4: middle estimate off by 4.3-fold (0.64 log units), on the high side; the measured number lies below the stated range.
By their numbers in this assay, from the lowest: compounds 4, 3 and 2 (each within the scatter of the next, the first and the last beyond it); then compound 1.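

In this assay the swap at this position gives a 42-fold lower number from compound 1 to compound 4 (1.62 log units; beyond the scatter) with the shared core and the methyl-bearing ring left as they are. Within the data shown here, compounds 2 and 3 each differ from compound 1 in more than one place, so only this step ties a large change in the number to the group on this chain alone. No measured evidence is at hand on why the step is so large.

Two things change together here, the link atom and the presence of a six-membered aromatic ring, so the step cannot be divided between them. A phenylamino group would keep the aromatic ring with a nitrogen link, while a cyclohexyloxy group would keep the oxygen link with a saturated ring, and either would help separate the two.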